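The source may report more compounds than this note shows. Statements on the series, on what has been measured and on what is new or still open speak of the compounds shown alone.

In an ADME assay on HEK293 cells (Homo sapiens) for cytotoxicity, read by MTT assay, with a stated time of 72 h (a lower number here means a stronger inhibitor, a higher number a weaker inhibitor), compound 1 `COc1ccc(C2=C(c3cc(OC)c(OC)c(OC)c3)C(=O)C(OC(C)=O)C2)cc1OC(C)C` gives > 100 ug/mL, which is a limit of the assay and not a number. Compound 2 `COc1ccc(C2=C(c3cc(OC)c(OC)c(OC)c3)C(=O)C(O[SiH2]C(C)(C)C)C2)cc1OC(C)C` gives > 100 ug/mL, also a limit and not a number. Compound 2 therefore stands at the limit of > 100 ug/mL in this assay, at which 2 of the 2 values shown sit, with no measured number to fix its place. Going by the values given here, the one measured step is a step that the two limits leave unreadable from compound 1 to compound 2, so it offers no size to carry forward. It does show that the group on this oxygen has been exchanged once without either compound leaving the limit.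

Compound 3 `COc1ccc(C2=C(c3cc(OC)c(OC)c(OC)c3)C(=O)C(O)C2)cc1OC(C)C` differs from compound 2 by a single change at the same place: a hydrogen atom in place of a group of 5 heavy atoms (4 carbon, 1 silicon; no ring), on an oxygen on a saturated carbon. The expectation rests on compound 2 with > 100 ug/mL, a limit, and it points to no step beyond the scatter in this assay and to no particular direction. The size expected is a number no higher from compound 2 to compound 3 (the limit leaves the size open), and a result reported only as a limit would be no surprise. Compound 3 is expected at 100 ug/mL, with an estimated range of 30 ug/mL to 150 ug/mL.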

Compound 3, half-maximal inhibitory concentration: > 100 ug/mL
Compound 3: no number, only a limit; the forecaster's own chance of this, stated with the estimate: 65%; the middle value lies on the limit itself.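

Compound 3 gives > 100 ug/mL, a limit and not a number. Going by these compounds alone, no step among compound 1, compound 2 and compound 3 can be read, and the three stand together: the limit of > 100 ug/mL in this assay, at which 3 of the 3 values shown sit. The compounds shown leave open what number each would have, and whether any group on this oxygen brings a value off the limit.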